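This account rests on a few compounds, and the source may have more. Where it says the series, first, only, none or still open, it means among the compounds named here.

Compound 1 `Cc1noc(NS(=O)(=O)c2cccc3c(NC(=O)C(C)C)cccc23)c1C` gives 880 nM in an assay on VSM-A10 cells for antagonist activity at Endothelin-1 receptor (Rattus norvegicus) (on this read-out higher numbers stand for weaker inhibition and lower numbers for stronger inhibition), the higher of the two values measured there. Compound 2 `Cc1noc(NS(=O)(=O)c2ccc3cc(N)ccc3c2)c1C` gives 660 nM in this assay, a value within the scatter of that of compound 1, so the two show no real difference. Compound 3 `Cc1noc(NS(=O)(=O)c2cccc3c(N/C(S)=N/c4ccccc4)cccc23)c1C` has not yet been measured. It differs from compound 1 in one place: a group of 9 heavy atoms (7 carbon, 1 nitrogen, 1 sulfur; one six-membered aromatic ring of carbon only) in place of a group of 5 heavy atoms (4 carbon, 1 oxygen; no ring), on a nitrogen on an aromatic ring. Among the measured compounds shown here, no measured pair shows a change of this kind, so the direction of the step is open. Compound 3 is expected to give about 500 nM in this assay, within 100 nM to 3000 nM. The estimated step of a 1.8-fold lower number from compound 1 to compound 3 (0.25 log units; within the scatter) is expected to stay within the scatter.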

Compound 3, half-maximal inhibitory concentration: 150 nM
Compound 3: the middle estimate sits 3.3-fold (0.52 log units) above what was measured; the range from low to high includes it.
By their numbers in this assay, from the lowest: compound 3; then compounds 2 and 1 (each within the scatter of the next).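

Putting the larger group with its six-membered aromatic ring of carbon only in place of isopropylcarbonyl, on a nitrogen on an aromatic ring, gives in this assay a 5.9-fold lower number from compound 1 to compound 3 (0.77 log units; beyond the scatter) and so shows that this position accepts a bigger group with a ring and no loss of inhibition. Nothing measured on these compounds accounts for the change. The ring, the added hydrogen-bond donor and the sulfur all enter together, so the compounds shown do not separate them. Going by these compounds, whether a benzoyl group, a urea or a longer alkyl chain on that nitrogen would do the same remains open.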